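A few compounds are considered here, and "the series" means these few. Any claim that something is new, unique, unknown or untested is made for them only; others in the source may bear on it.

Measured compounds:
compound 1, `COc1ccc(-c2cc(/C=C/C(=O)c3ccc(N)cc3)[nH]n2)cc1`, gives 2140 nM in a functional assay on MDA-MB-231 cells (Homo sapiens) for inhibition, read by sulforhodamine B assay, with a stated time of 48 h; on this read-out lower numbers stand for stronger inhibition of growth and higher numbers for weaker inhibition of growth.
compound 2, `COc1cc(-c2cc(/C=C/C(=O)c3ccc(N)cc3)[nH]n2)cc(OC)c1OC`, gives 2060 nM in this assay.

Compound 2 and compound 1 sit within the scatter of each other, so compound 2 is not set apart from compound 1 on the numbers shown; for working purposes the two readings agree. Compound 3, `COc1ccc(-c2cc(/C=C/C(=O)c3ccc(N)cc3)[nH]n2)cc1OC`, is not yet measured in this assay. Compared with compound 2, the change is hydrogen in place of methoxy on an aromatic carbon. Among the compounds with values here, no step between measured compounds is known. Since compound 1 with 2140 nM and compound 2 with 2060 nM differ in methoxy substitution on that ring and still agree, a step of no size beyond the scatter is expected in this assay, in no set direction. Compound 3 is therefore estimated at 2000 nM, with a range of 900 nM to 4500 nM. The expected step is a 1.0-fold lower number from compound 2 to compound 3 (0.01 log units; within the scatter).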

Compound 3, concentration for 50% growth inhibition: 4420 nM
The estimate for compound 3 lay 2.2-fold (0.34 log units) below the measured number; the measured number falls inside the stated range.
By their numbers in this assay, from the lowest: compounds 2 and 1 (each within the scatter of the next); then compound 3.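

In this assay, within the data shown here, taking away a methoxy group from an aromatic carbon ortho to a methoxy group and meta to a large group gives a 2.1-fold higher number from compound 2 to compound 3 (0.33 log units; beyond the scatter), the first step beyond the scatter. Putting methoxy in place of hydrogen on an aromatic carbon gives a 2.1-fold higher number from compound 1 to compound 3 (0.32 log units; beyond the scatter), so the number rises both when a methoxy group leaves and when one enters, and methoxy count does not move it in one direction across these compounds. No measurement shown accounts for either step.

Going by these compounds, whether compound 3 is a dip peculiar to its particular methoxy pattern remains open, as these steps rest on three compounds only. Also open, on these data alone, is how a hydroxy group, an ethoxy group or a chlorine atom on this aromatic carbon would read in this assay.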